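A few compounds are considered here, and "the series" means these few. Any claim that something is new, unique, unknown or untested is made for them only; others in the source may bear on it.

Compound 2 `COC(=O)CSc1nc(N)c(C#N)c(-c2ccc(OCC3CC3)cc2)c1C#N` belongs to a small set of compounds built on one shared core. Among the compounds with values here, in an assay on CHO cells for displacement of a labelled ligand from adenosine receptor A3 (Homo sapiens), read by scintillation counting, with a stated time of 120 min, tested at 1 uM (on this read-out higher numbers stand for more inhibition at the one concentration tested (going by the name of the read-out) and lower numbers for less inhibition), compound 2 gives 1%, the lower of the two numbers recorded so far, though the gap to its only neighbour lies within the scatter. That neighbour, compound 1 `N#Cc1c(N)nc(SCc2ccn[nH]2)c(C#N)c1-c1ccc(OCC2CC2)cc1`, differs from it in one place and in this assay compound 1 gives 6%. Compound 3 `N#Cc1c(N)nc(SCc2ncn[nH]2)c(C#N)c1-c1ccc(OCC2CC2)cc1` has not yet been measured. It differs from compound 2 in a single place: 1H-1,2,4-triazol-5-yl in place of methoxycarbonyl on a saturated chain carbon bound to a sulfur. Within the data shown here, the one measured step that bears on this change is the exchange of 1H-pyrazol-5-yl for methoxycarbonyl on the saturated chain carbon bound to a sulfur, and it was small, a number 5 percentage points lower from compound 1 to compound 2 (within the scatter). Putting a five-membered aromatic ring back in place of methoxycarbonyl at the same position is therefore expected to give no step beyond the scatter in this assay. For compound 3 the estimate is 5%, with a range from 0% to 15%. This corresponds to an expected step of a number 4 percentage points higher from compound 2 to compound 3 (within the scatter).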

Compound 3, a percentage reported as inhibition, at one concentration (the size of the read-out at that concentration, not a potency): 1%
Compound 3: middle estimate off by 4 percentage points, on the high side; the range from low to high includes it.
By their numbers in this assay, from the lowest: compounds 2, 3 and 1 (each within the scatter of the next).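

In this assay, putting 1H-1,2,4-triazol-5-yl in place of methoxycarbonyl on a saturated chain carbon bound to a sulfur gives no change at the digits printed from compound 2 to compound 3 (within the scatter) and putting it in place of 1H-pyrazol-5-yl at the same place gives a number 5 percentage points lower from compound 1 to compound 3 (within the scatter) as its result. This position has now carried three different groups, two of them five-membered aromatic rings and one of them without a ring, and every step among these three compounds stays within the scatter, so the read-out at this one concentration separates neither the two rings from each other nor either ring from methoxycarbonyl. Nothing measured on these compounds offers an explanation for this lack of separation.

The compounds shown leave open whether any other group on this saturated chain carbon, such as an amine, a carboxylic acid or a longer chain, would move the number beyond the scatter. They also leave open whether the three compounds would still fall within the scatter of one another at a higher concentration, since a single concentration gives no potency.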